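The source may report more compounds than this note shows. Statements on the series, on what has been measured and on what is new or still open speak of the compounds shown alone.

Measured so far in a functional assay on HCT-116 cells (Homo sapiens) for antiproliferative activity, read by MTT assay, with a stated time of 48 h; a higher number here means a weaker inhibitor, a lower number a stronger inhibitor:
Compound 1, `O=C(/C=C/c1cccnc1)c1nc2ccccc2[nH]1`: 15300 nM
Compound 2, `O=C(/C=C/c1cccc(Cl)c1)c1nc2ccccc2o1`: > 100000 nM, which is a limit of the assay, not a number.

Compound 1 and compound 2 carry the same carbonyl-linked propenyl bridge between a bicyclic core and a six-membered aromatic ring, yet they differ both in the core and in the far ring, so no single change can be read between their two values. Compound 2 stands at the limit of > 100000 nM in this assay, at which 1 of the 2 values shown sits, the weaker end of what the assay can report. Compound 3, `COc1cccc(/C=C/C(=O)c2nc3ccccc3o2)c1`, keeps the whole of compound 2 except at the far ring, where the change is this: methoxy in place of chloro on an aromatic carbon. Nothing measured here speaks to what this swap does, since compound 2 gives only a limit. The step of an at least 1.2-fold lower number from compound 2 to compound 3 (0.09 log units; that floor lies within the scatter) is therefore expected to be small, with compound 3 most likely staying weak in this assay and a fair chance that it too returns only a limit. Compound 3 is estimated at 80000 nM, within a range from 25000 nM to 250000 nM.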

Compound 3, half-maximal inhibitory concentration: > 100000 nM
Compound 3 gave a limit, no number; the forecaster's own chance of this, stated with the estimate: 55%; at least 1.2-fold (0.09 log units) between middle value and limit.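

No step can be read between compound 2 and compound 3, because both return only a limit of the assay, not a number: the limit of > 100000 nM in this assay, at which 2 of the 3 values shown sit.

The compounds shown leave open how far methoxy and chloro on this far ring actually differ in this assay, since neither compound has a measured value there.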